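The compounds below may be only part of what the source reports. "The series", "measured", "known", "first", "only" and "open" are said of these compounds alone.

Measured in an assay on isolated protein for displacement of a labelled ligand from melanin-concentrating hormone receptor 1 (Homo sapiens); a higher number here means a weaker inhibitor, a lower number a stronger inhibitor:

compound 1 `CCCc1ccc(/C=C/C(=O)Nc2ccc3nc(CCC)cc(N)c3c2)cc1`: 4 nM
compound 2 `CCCc1cc(N)c2cc(NC(=O)/C=C/c3ccc(N)cc3)ccc2n1`: 190 nM
compound 3 `CCCc1cc(N)c2cc(NC(=O)/C=C/c3ccc(F)cc3)ccc2n1`: 130 nM

Compound 3 stands at the second highest of the three numbers. a 1.5-fold lower number from compound 2 to compound 3 (0.16 log units; within the scatter), so compounds 2 and 3 cannot be told apart. a 33-fold higher number from compound 1 to compound 3 (1.51 log units; beyond the scatter), the one large gap in the set.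

Compound 4 `CCCc1cc(N)c2cc(NC(=O)/C=C/c3ccc(C(C)C)cc3)ccc2n1` differs from compound 3 by isopropyl in place of fluoro on an aromatic carbon. The step that bears on it is the reverse of the step from compound 1 to compound 3, where a three-carbon chain was replaced by fluorine: a 33-fold higher number from compound 1 to compound 3 (1.51 log units; beyond the scatter). Isopropyl is again a three-carbon group, so a large step back down in this assay is expected: a 13-fold lower number from compound 3 to compound 4 (1.11 log units; beyond the scatter). Compound 4 is therefore estimated at 10 nM, with a range of 3 nM to 40 nM.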

Compound 4, half-maximal inhibitory concentration: 2.9 nM
Beside the measured number, compound 4's estimate is 3.4-fold (0.54 log units) above it; the measured number lies below the stated range.
By their numbers in this assay, from the lowest: compounds 4 and 1 (each within the scatter of the next); then compounds 3 and 2 (each within the scatter of the next).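

Working from this assay, the change from 4-fluorophenyl to 4-isopropylphenyl is large (a 45-fold lower number from compound 3 to compound 4 (1.65 log units; beyond the scatter)), and isopropyl in place of amino is similarly large (a 66-fold lower number from compound 2 to compound 4 (1.82 log units; beyond the scatter)). Isopropyl and propyl at this position cannot be told apart (a 1.4-fold lower number from compound 1 to compound 4 (0.14 log units; within the scatter)), so the low number seen with propyl in compound 1 is not unique to that chain.

From the compounds shown here alone, how a longer chain, a tert-butyl group or a cyclopropyl ring would read at this position remains open. Nothing on hand accounts for these steps.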